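The source may report more compounds than this note shows. Statements on the series, on what has been measured and on what is new or still open speak of the compounds shown alone.

Working notes on the series. Compound 1 `CCCCCCCCc1cn([C@H]2C[C@H](O)[C@@H](CO)O2)c(=O)[nH]c1=O` gives 140 ug/mL in a functional assay on Raji cells (Homo sapiens); on this read-out higher numbers stand for weaker inhibition and lower numbers for stronger inhibition. Compound 2 `CCCCCCc1cn([C@H]2C[C@H](O)[C@@H](CO)O2)c(=O)[nH]c1=O` gives 173 ug/mL in this assay. Among the measured compounds shown here, the only measured change at the chain is a 1.2-fold higher number from compound 1 to compound 2 (0.09 log units; within the scatter), so shortening the chain here left the read-out where it was.

Compound 3 `CCCCCCc1cn([C@H]2C[C@@H]3OP(=O)(O)OC[C@H]3O2)c(=O)[nH]c1=O` stands apart in the sugar part of the core. In this assay compound 3 reaches only a limit, > 500 ug/mL, which is a limit of the assay and not a number; this is the limit of > 500 ug/mL in this assay, at which 1 of the 3 values shown sits.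

Compound 4 `CCCCCc1cn([C@H]2C[C@@H]3OP(=O)(O)OC[C@H]3O2)c(=O)[nH]c1=O` has not yet been measured. It differs from compound 3 by hydrogen in place of methyl on a saturated chain carbon, five bonds along the chain from an aromatic carbon. For the measured compounds named here, the one step that bears on this kind of change is a 1.2-fold higher number from compound 1 to compound 2 (0.09 log units; within the scatter), a shortening of the same chain that stayed within the scatter. No step beyond the scatter is expected in this assay from compound 3 to compound 4.

Compound 4 is therefore estimated at 600 ug/mL in this assay, with a range from 250 ug/mL to 1500 ug/mL, most likely reported again only as a limit.

The estimated step from compound 3 to compound 4 is a step that the limit leaves unreadable from compound 3 to compound 4.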

Compound 4, concentration for 50% inhibition: > 500 ug/mL
Compound 4 gave a limit, no number; the forecaster's own chance of this, stated with the estimate: 80%; the middle value is on the limit's open side.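

Compound 3 and compound 4 both end at a limit of the assay and not a number in this assay, so no step can be read between them: the limit of > 500 ug/mL in this assay, at which 2 of the 4 values shown sit.

The compounds shown leave open whether shortening the chain changes the read-out at all on the sugar part shared by compound 3 and compound 4.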